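Piperidinyl Ether Replaces Cyclohexyl Ether on a Sulfone

The source may hold more compounds than are shown below. What is called first, only, known or untested is meant among the compounds shown, and "the series" means these compounds.

Compound 1 `Cc1cc(C)c(S(=O)(=O)c2ccc(I)cc2)c(C)c1` gives 4000 nM in an assay on isolated protein for antagonist activity at Rap guanine nucleotide exchange factor 4 (Homo sapiens), read by fluorescence and cAMP accumulation; a lower number here means a stronger inhibitor, a higher number a weaker inhibitor. Compound 2 `Cc1cc(C)c(S(=O)(=O)c2ccc(OC3CCCCC3)cc2)c(C)c1` reaches only a limit of this assay, > 300000 nM, and no number. For the measured compounds named here, the single measured step, an at least 75-fold higher number from compound 1 to compound 2 (1.87 log units; beyond the scatter), alters an aromatic carbon and leaves the cyclohexyloxy group untouched, so it offers no direct guide to the change ahead. Compound 3 `Cc1cc(C)c(S(=O)(=O)c2ccc(OC3CCNCC3)cc2)c(C)c1` differs from compound 2 by piperidin-4-yl in place of cyclohexyl on an oxygen on an aromatic ring. Going by the values given here, with compound 2 fixed only at a limit and no comparable step measured, compound 3 is expected near 200000 nM, between 30000 nM and 1000000 nM, a step of an at least 1.5-fold lower number from compound 2 to compound 3 (0.17 log units; that floor lies within the scatter) that may again end as a limit.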

Compound 3, half-maximal inhibitory concentration: > 300000 nM
Compound 3: a limit, no number; the forecaster's own chance of this, stated with the estimate: 60%; middle value at least 1.5-fold (0.17 log units) away from the limit.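

In this assay compound 3 gives only a limit, > 300000 nM, and no number. Set against the iodo group, the (piperidin-4-yl)oxy group gives an at least 75-fold higher number from compound 1 to compound 3 (1.87 log units; beyond the scatter), so a second ether on this aromatic carbon also lies far from compound 1. The change from cyclohexyl to piperidin-4-yl cannot itself be read, since both ends of that step are limits: the limit of > 300000 nM in this assay, at which 2 of the 3 values shown sit.

Still open, going by these compounds, is whether a smaller group on this aromatic carbon, such as methoxy or a plain amine, would give a readable number.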